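A few compounds are considered here, and "the series" means these few. Any claim that something is new, unique, unknown or untested is made for them only; others in the source may bear on it.

Measured so far:
Compound 1 `COc1ccc(Cn2cc(CNC(=O)c3cn(-c4ccccc4)nc3-c3ccc(F)cc3)nn2)cc1OC` gives > 100000 nM in a functional assay on MCF7 cells (Homo sapiens) for antiproliferative activity, read by sulforhodamine B assay, with a stated time of 48 h; on this read-out higher numbers stand for weaker inhibition of growth and lower numbers for stronger inhibition of growth; this is a limit of the assay, not a number.
Compound 2 `COc1cc(Cn2cc(CNC(=O)c3cn(-c4ccccc4)nc3-c3ccc(F)cc3)nn2)cc(OC)c1` gives 2500 nM in this assay.
Compound 3 `COc1ccc(-c2nn(-c3ccccc3)cc2C(=O)NCc2cn(Cc3ccc(OC)c(OC)c3)nn2)cc1` gives > 100000 nM in this assay; this too is a limit, not a number.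

Among the measured compounds shown here, the only change between compound 1 and compound 2 is 3,5-dimethoxyphenyl in place of 3,4-dimethoxyphenyl on a saturated chain carbon bound to an aromatic nitrogen. That change produced an at least 40-fold lower number from compound 1 to compound 2 (1.60 log units; beyond the scatter). Compound 4 `COc1ccc(-c2nn(-c3ccccc3)cc2C(=O)NCc2cn(Cc3cc(OC)cc(OC)c3)nn2)cc1` has not yet been measured. It differs from compound 3 by 3,5-dimethoxyphenyl in place of 3,4-dimethoxyphenyl on a saturated chain carbon bound to an aromatic nitrogen, the same change at the same place. The cores of compound 1 and compound 3 differ by methoxy in place of fluoro on an aromatic carbon, and for this pair the data give a step that the two limits leave unreadable from compound 1 to compound 3. Two of the three known values sit at the limit of > 100000 nM in this assay, at which 2 of the 3 values shown sit, so the effect of the methoxy-for-fluoro change cannot be read.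

For compound 3 to compound 4 in this assay, a step of about an at least 12-fold lower number from compound 3 to compound 4 (1.09 log units; beyond the scatter) is expected, resting on the comparable an at least 40-fold lower number from compound 1 to compound 2 (1.60 log units; beyond the scatter) and the shared starting point at the assay limit. Because of the uncertainty around compound 3 with > 100000 nM, the range is wide. Compound 4 is estimated at 8000 nM, expected to lie between 1500 nM and 60000 nM.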

Compound 4, concentration for 50% growth inhibition: 700 nM
Estimate against measurement, compound 4: 11-fold (1.06 log units) above; the whole stated range lies above it.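

In this assay the swap of 3,4-dimethoxybenzyl for 3,5-dimethoxybenzyl also works on a second core and gives an at least 140-fold lower number from compound 3 to compound 4 (2.15 log units; beyond the scatter). The change therefore points the same way on both cores, but its size cannot be compared: the same change on two cores in this assay, an at least 40-fold lower number (1.60 log units; beyond the scatter) from compound 1 to compound 2 and an at least 140-fold lower number (2.15 log units; beyond the scatter) from compound 3 to compound 4; the limit leaves it open whether they differ. Going by these compounds, compound 1 and compound 3 each stand at a limit and not at a number, so the true size of each step stays unknown, and two cores do not make a general rule: the limit of > 100000 nM in this assay, at which 2 of the 4 values shown sit.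

On these data alone, with the 3,5-dimethoxybenzyl group in place, methoxy in place of fluoro gives a 3.6-fold lower number from compound 2 to compound 4 (0.55 log units; beyond the scatter), while the matching step between the two limits cannot be read, so it remains open whether this gain holds with the 3,4-dimethoxybenzyl group. The compounds shown also leave open what a benzyl group carrying a single methoxy would do, or an amine, a carboxylic acid or a longer chain in place of the dimethoxybenzyl group.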